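Swapping the pyrazole for a pyridine on the shared core

A few compounds are considered here, and "the series" means these few. Any claim that something is new, unique, unknown or untested is made for them only; others in the source may bear on it.

Compound 3, with the structure `CC(c1c(F)cc2ncccc2c1F)n1cnc2ncc(-c3cnn(CCO)c3)nc21`, is the compound with the lowest number among the three measured here: in an ADME assay on microsomes from liver (Rattus norvegicus) for metabolic stability, read by LC-MS, using NADPH, with stated times of 5 min and 30 min, tested at 1 uM (on this read-out lower numbers stand for slow clearance and higher numbers for fast clearance), compound 3 gives 10 uL/min. Compound 1 `CC(c1cc2cccnc2cc1F)n1cnc2ncc(-c3cnn(C)c3)nc21` gives 18 uL/min in this assay, and compound 2 `CC(c1c(F)cc2ncccc2c1F)n1cnc2ncc(-c3cnn(C)c3)nc21` gives 63 uL/min. Within the data shown here, the step of a 3.5-fold higher number from compound 1 to compound 2 (0.54 log units; beyond the scatter) and the step of a 6.3-fold lower number from compound 2 to compound 3 (0.80 log units; beyond the scatter) are the only two single changes measured so far.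

Compound 4 `CC(c1c(F)cc2ncccc2c1F)n1cnc2ncc(-c3ccncc3)nc21` differs from compound 3 in one place: pyridin-4-yl in place of 1-(2-hydroxyethyl)-1H-pyrazol-4-yl on an aromatic carbon. Among the measured compounds shown here, no measured step covers the exchange of one ring for another, so only the loss of the hydroxyethyl group can be weighed. The step of a 6.3-fold lower number from compound 2 to compound 3 (0.80 log units; beyond the scatter) shows what adding that group did; compound 4 gives it up, so the number is expected to move back upward, though the new ring makes the size uncertain. For compound 4 the expected step is a 3.5-fold higher number from compound 3 to compound 4 (0.54 log units; beyond the scatter), with a value in this assay estimated at 35 uL/min, most likely between 12 uL/min and 90 uL/min.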

Compound 4, intrinsic clearance in a liver preparation (reported as CLH), per the amount of preparation that the assay uses: 77 uL/min
The estimate for compound 4 lay 2.2-fold (0.34 log units) below the measured number; the measured number falls inside the stated range.
By their numbers in this assay, from the lowest: compounds 3 and 1 (each within the scatter of the next); then compounds 2 and 4 (each within the scatter of the next).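

In this assay, the exchange of the ring on this aromatic carbon gives a 7.7-fold higher number from compound 3 to compound 4 (0.89 log units; beyond the scatter) and so undoes the gain seen with the hydroxyethyl group. The exchange of the methylated ring, a 1.2-fold higher number from compound 2 to compound 4 (0.09 log units; within the scatter), lies within the scatter, so 1-methyl-1H-pyrazol-4-yl and pyridin-4-yl cannot be told apart here. With the rest of the structure unchanged across compounds 2, 3 and 4, only 1-(2-hydroxyethyl)-1H-pyrazol-4-yl goes with a clearly lower number, and nothing available explains why the numbers differ.

From the compounds shown here alone, it remains open whether that low number depends on the hydroxyethyl chain alone or on that chain sitting on a pyrazole, which a pyridine carrying the same chain would help to separate. Going by these compounds, the effect of a longer chain, or of an amine or a carboxylic acid in place of the hydroxyl group, also remains open.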